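Methyl on the Phenyl Ring: Expected Cost in Cytotoxicity

The compounds below may be only part of what the source reports. "The series", "measured", "known", "first", "only" and "open" are said of these compounds alone.

Compound 1 `O=S(=O)(c1ccccc1)c1nc2ccccc2nc1N1CCCC1`: 20800 nM
Compound 2 `Cc1ccc(S(=O)(=O)c2nc3ccccc3nc2N2CCCC2)cc1`: > 50000 nM, a limit of the assay rather than a number
Compound 3 `O=S(=O)(c1ccccc1)c1nc2ccccc2nc1N1CCCC(O)C1`: 2100 nM

Three compounds were measured in a functional assay on PC-3 cells (Homo sapiens) for cytotoxicity, read by MTT assay, with a stated time of 72 h; on this read-out lower numbers stand for stronger inhibition and higher numbers for weaker inhibition. Compound 1 gives 20800 nM. Compound 3 gives 2100 nM, the lowest number found, and it differs from compound 1 by 3-hydroxypiperidin-1-yl in place of pyrrolidin-1-yl on an aromatic carbon, a change that brought a 9.9-fold lower number from compound 1 to compound 3 (1.00 log units; beyond the scatter). Compound 2 reached only a limit of the assay, > 50000 nM, so its step from compound 1 is known as a bound: an at least 2.4-fold higher number from compound 1 to compound 2 (0.38 log units; beyond the scatter), where the limit of > 50000 nM in this assay, at which 1 of the 3 values shown sits, marks the edge of what was seen. That step is methyl in place of hydrogen on an aromatic carbon.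

Compound 4 `Cc1ccc(S(=O)(=O)c2nc3ccccc3nc2N2CCCC(O)C2)cc1` is not yet measured. It differs from compound 3 by methyl in place of hydrogen on an aromatic carbon, the same change made from compound 1 to compound 2, at the same place by every word of the description, so the pair is a true repeat of that change on the core of compound 3. Because compound 1 gave 20800 nM and compound 2 only > 50000 nM, the weakening is expected to recur: compound 4 is estimated at a 3.8-fold higher number from compound 3 to compound 4 (0.58 log units; beyond the scatter), with the size uncertain since the first step is only a bound. The expected value for compound 4 in this assay is 8000 nM, between 2500 nM and 40000 nM.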

Compound 4, half-maximal inhibitory concentration: 5330 nM
Estimate against measurement, compound 4: 1.5-fold (0.18 log units) above; low and high end bracket the measured number.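

In this assay the methyl, on an aromatic carbon para to a large group, again went with a higher number on the core of compound 3, with a 2.5-fold higher number from compound 3 to compound 4 (0.40 log units; beyond the scatter), so the direction of the change carried from one core to the other: the same change on two cores in this assay, an at least 2.4-fold higher number (0.38 log units; beyond the scatter) from compound 1 to compound 2 and a 2.5-fold higher number (0.40 log units; beyond the scatter) from compound 3 to compound 4; the limit leaves it open whether they differ. The exchange of pyrrolidin-1-yl for 3-hydroxypiperidin-1-yl also held its direction with the 4-methylphenyl group in place, with an at least 9.3-fold lower number from compound 2 to compound 4 (0.97 log units; beyond the scatter): the same change on two cores in this assay, a 9.9-fold lower number (1.00 log units; beyond the scatter) from compound 1 to compound 3 and an at least 9.3-fold lower number (0.97 log units; beyond the scatter) from compound 2 to compound 4; the limit leaves it open whether they differ. Compound 2 gives > 50000 nM, a limit of the assay, so these pairs show a shared direction and not a shared size, and they speak for these two cores alone.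

The compounds shown leave open how much of the lower number belongs to the hydroxy group and how much to the piperidine ring, as both arrive in a single step. Also open, on these data alone, is how a chlorine atom or a methoxy group would behave in place of the methyl on the phenyl ring.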